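Adding a Methyl to a Branched Chain: Dose Expected

The compounds below may be only part of what the source reports. "The series", "measured", "known", "first", "only" and "open" are said of these compounds alone.

Compound 1 `CCCC/N=C(\NC#N)Nc1cccnc1`: 20 mg/kg in a functional assay on the whole organism (blood, strain Wistar-Okamoto) with Rattus norvegicus as the target, with a stated time of 5 days; a lower number here means that less compound is needed, a higher number that more compound is needed for the effect
Compound 2 `CCCCC/N=C(\NC#N)Nc1cccnc1`: 20 mg/kg in this assay
Compound 3 `CCC(C)(C)/N=C(\NC#N)Nc1ccncc1`: 2.5 mg/kg in this assay

Compound 1 and compound 2 share a core; compound 2 carries one more carbon on the chain. That change, (methyl in place of hydrogen on a saturated chain carbon, four bonds along the chain from a double-bonded nitrogen), gave no change at the digits printed from compound 1 to compound 2 (within the scatter). Compound 3 has a different core and a branched chain; the difference between the two cores is not broken down here. In this assay compound 3 gives 2.5 mg/kg, the lowest number of the three, beyond the scatter from both others.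

Compound 4 `CC(C)C(C)(C)/N=C(\NC#N)Nc1ccncc1` is not yet measured. It differs from compound 3 by methyl in place of hydrogen on a saturated chain carbon bound to two saturated chain carbons. This is the same kind of change as from compound 1 to compound 2, though the place differs: there the carbon was four bonds along the chain from a double-bonded nitrogen, here it is bound to two saturated chain carbons. Because no change at the digits printed from compound 1 to compound 2 (within the scatter) was within the scatter, a similarly small step is expected, no change at the digits printed from compound 3 to compound 4 (within the scatter). Compound 4 is therefore estimated at 2.5 mg/kg, between 1.2 mg/kg and 6 mg/kg.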

Compound 4, minimum effective dose: 20 mg/kg
Estimate against measurement, compound 4: 8.0-fold (0.90 log units) below, and the stated range ends below it.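

In this assay, putting methyl in place of hydrogen on a saturated chain carbon bound to two saturated chain carbons gave an 8.0-fold higher number from compound 3 to compound 4 (0.90 log units; beyond the scatter), so more compound is needed for the effect after this change. A methyl step that left the number unmoved on one core therefore cannot be assumed to do the same on the other: the same change on two cores in this assay, no change at the digits printed (within the scatter) from compound 1 to compound 2 and an 8.0-fold higher number (0.90 log units; beyond the scatter) from compound 3 to compound 4, 8.0-fold (0.90 log units) apart, beyond the scatter of two such steps

This does not show that the core alone sets the size of the step, since the methyl also sits at a different place on the chain in the two pairs, and a single pair on each core gives no general rule.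

The compounds shown leave open how the 1,1,2-trimethylpropyl chain would read on the core of compound 1, which would separate the effect of the core from that of the place. They also leave open how a hydroxyl group, an amine or a longer chain at that same place would compare with methyl.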